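Enlarging the Acetyl Group of Compound 1

This account rests on a few compounds, and the source may have more. Where it says the series, first, only, none or still open, it means among the compounds named here.

Measured so far:
compound 1, `CCCc1c(OCCCCOc2ccc(-c3nn[nH]n3)cc2)ccc(C(C)=O)c1O`, gives 348 nM
compound 2, `CCCc1c(OCCCC(C)Oc2ccc(-c3nn[nH]n3)cc2)ccc(C(C)=O)c1O`, gives 495 nM
compound 3, `CC(=O)c1ccc(OCCCCOc2ccc(-c3nn[nH]n3)cc2)c(Br)c1O`, gives 878 nM

In an assay on isolated protein for binding affinity to metabotropic glutamate receptor 2 (Homo sapiens), read by GTPgammaS binding (a higher number here means that more compound is needed for the effect, a lower number that less compound is needed), compound 1 holds the lowest of the three numbers. Its nearest neighbour is compound 2, reached by a 1.4-fold higher number from compound 1 to compound 2 (0.15 log units; within the scatter), and its furthest is compound 3, reached by a 2.5-fold higher number from compound 1 to compound 3 (0.40 log units; beyond the scatter). Compound 4, `CCCc1c(OCCCCOc2ccc(-c3nn[nH]n3)cc2)ccc(C(=O)CC(C)C)c1O`, is not yet measured. It differs from compound 1 in one place: isopropyl in place of hydrogen on a saturated chain carbon bound to a carbonyl carbon. Neither of the measured steps touches this part of the shared core. The step from compound 1 to compound 2 alters the chain between the two aryl ethers, and the step from compound 1 to compound 3 exchanges the propyl group on the ring; both leave the acetyl untouched. Within the data shown here, the only guidance these steps offer is that one change on the linker stayed within the scatter while one change on the ring moved the number modestly upward. Among the measured compounds shown here, with no step at the carbonyl side to lean on, compound 4 is expected to land near compound 1, with a 1.2-fold higher number from compound 1 to compound 4 (0.08 log units; within the scatter) as the estimated step and a wide range. Compound 4 is therefore estimated at 420 nM, between 150 nM and 1200 nM.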

Compound 4, half-maximal effective concentration: 421 nM
Compound 4: middle estimate off by 1.0-fold (0.00 log units), on the low side; the measured number falls inside the stated range.
By their numbers in this assay, from the lowest: compounds 1, 4, 2 and 3 (each within the scatter of the next, the first and the last beyond it).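

In this assay, among these compounds, the step at this position reads a 1.2-fold higher number from compound 1 to compound 4 (0.08 log units; within the scatter), and it is the first reading at the acetyl, which both earlier steps left untouched. It shows that isopropyl can enter on the saturated chain carbon bound to a carbonyl carbon, turning acetyl into isobutylcarbonyl and adding 3 carbon heavy atoms, while compound 4 stays indistinguishable from compound 1, unlike the exchange of propyl for bromo, which gave a 2.5-fold higher number from compound 1 to compound 3 (0.40 log units; beyond the scatter). Nothing shown here bears on the reason for this result.

On these data alone, with a single group at this position, it remains open whether a longer chain, a phenyl ring or an amine on the same carbon would also stay within the scatter of compound 1, and a single reading cannot show how far this position extends. As far as these compounds go, it is equally open whether isobutylcarbonyl would read the same on the core of compound 3, which carries bromo, or alongside the added methyl of compound 2.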